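The source may hold more compounds than are shown below. What is called first, only, known or untested is meant among the compounds shown, and "the series" means these compounds.

Measured so far:
compound 1, `N=c1sc(=S)[nH]c2c1cc(-c1ccccc1)n2-c1ccccc1`, 0%
compound 2, `N=c1sc(=S)[nH]c2c1cc(-c1ccc(Br)cc1)n2-c1ccccc1`, 44%
compound 3, `CCSc1nc2c(cc(-c3ccc(Cl)cc3)n2-c2ccccc2)c(=N)s1`, 1%

In a functional assay on the whole organism for inhibition, with Rattus norvegicus as the target, read by ELISA, with stated times of 30 min and 6 h, at a dose of 30 mg/kg by the oral route (on this read-out lower numbers stand for less inhibition and higher numbers for more inhibition at the one dose given (going by the name of the read-out)), compound 3 stands second highest of the three numbers. Its nearest neighbour is compound 1, whose value lies within the scatter of that of compound 3, and its furthest is compound 2, which stands well beyond the scatter. Compound 4 is `CCSc1nc2c(cc(-c3ccc(Br)cc3)n2-c2ccccc2)c(=N)s1`, and it differs from compound 3 by bromo in place of chloro on an aromatic carbon.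

Going by the values given here, only one measured step touches this change: a number 44 percentage points higher from compound 1 to compound 2 (beyond the scatter), a bromo in place of hydrogen on the same ring and at the same spot, but in a core without the ethylthio group. Among the compounds with values here, no measured pair shows bromo against chloro directly, and compounds 2 and 3 differ in two places at once, so their values can only be set side by side: compound 2 gives 44% while compound 3 gives 1%. A bromo in place of chloro is a smaller change than bromo in place of hydrogen, so only part of that large step is expected to carry over in this assay, upward, with a wide range. The expected step is a number 14 percentage points higher from compound 3 to compound 4 (beyond the scatter). Compound 4 is therefore estimated at 15%, between 0% and 40%.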

Compound 4, a percentage reported as inhibition, in the whole organism at one dose (the size of the read-out at that dose, not a potency): 1%
Estimate against measurement, compound 4: 14 percentage points above; low and high end bracket the measured number.
By their numbers in this assay, from the lowest: compounds 1, 3 and 4 (each within the scatter of the next); then compound 2.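

In this assay, bromo in place of chloro on the 4-chlorophenyl group gives no change at the digits printed from compound 3 to compound 4 (within the scatter), so on the core carrying the ethylthio group, this exchange of one halogen for another does not move the number. The same 4-bromophenyl group sits in two compounds that differ only by the ethyl group on sulfur: compound 2 gives 44% and compound 4 gives 1%, so the bromo group alone does not bring a high number, and the rise seen in a number 44 percentage points higher from compound 1 to compound 2 (beyond the scatter) does not by itself describe what bromo does on every core. No available evidence explains why these numbers fall as they do.

The compounds shown leave open whether a different kind of group at this spot, such as a methoxy group, or an amine in place of the ethylthio group, would lift the number on this core. They also leave open whether compound 3 and compound 4 would stay level at a dose other than the single one used here.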